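A few compounds are considered here, and "the series" means these few. Any claim that something is new, unique, unknown or untested is made for them only; others in the source may bear on it.

Three compounds share one core and differ only in the group attached to the saturated chain carbon bound to the amine nitrogen. Compound 1 `CC(C)(C)c1ccc(CNCCCNS(=O)(=O)c2cc(C(F)(F)F)cc(C(F)(F)F)c2)cc1` carries 4-(tert-butyl)phenyl there, compound 2 `O=S(=O)(NCCCNCc1ccc(C(F)(F)F)cc1)c1cc(C(F)(F)F)cc(C(F)(F)F)c1` carries 4-(trifluoromethyl)phenyl, and compound 3 `O=S(=O)(NCCCNCc1cccc2ccccc12)c1cc(C(F)(F)F)cc(C(F)(F)F)c1` carries naphthalen-1-yl. In a functional assay on PANC-1 cells (Homo sapiens) for inhibition, read by MTT assay, with a stated time of 72 h (a higher number here means a weaker inhibitor of growth, a lower number a stronger inhibitor of growth), compound 1 gives 2500 nM, compound 2 gives 3200 nM, and compound 3 gives 2700 nM. Compound 3 stands second highest of the three numbers, with compound 1 nearest and compound 2 furthest, and every step among them lies within the scatter: a 1.3-fold higher number from compound 1 to compound 2 (0.11 log units; within the scatter), a 1.1-fold higher number from compound 1 to compound 3 (0.03 log units; within the scatter), and a 1.2-fold lower number from compound 2 to compound 3 (0.07 log units; within the scatter). Compound 4 `COc1cccc(CNCCCNS(=O)(=O)c2cc(C(F)(F)F)cc(C(F)(F)F)c2)c1` keeps the same core, and the change is 3-methoxyphenyl in place of naphthalen-1-yl on a saturated chain carbon bound to an amine nitrogen. All three measured steps alter this same group, and none of them moved the number beyond the scatter, so no step beyond the scatter is expected in this assay here either. The expected step is a 1.1-fold higher number from compound 3 to compound 4 (0.05 log units; within the scatter). Compound 4 is therefore estimated at 3000 nM, with a range from 1200 nM to 7500 nM.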

Compound 4, concentration for 50% growth inhibition: 10000 nM
Beside the measured number, compound 4's estimate is 3.3-fold (0.52 log units) below it; the measured number lies above the stated range.
By their numbers in this assay, from the lowest: compounds 1, 3 and 2 (each within the scatter of the next); then compound 4.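

This position is less indifferent than the first three compounds suggested: in this assay, the change to 3-methoxyphenyl gives a 3.7-fold higher number from compound 3 to compound 4 (0.57 log units; beyond the scatter), and the matching changes give a 3.1-fold higher number from compound 2 to compound 4 (0.49 log units; beyond the scatter) and a 4.0-fold higher number from compound 1 to compound 4 (0.60 log units; beyond the scatter). Compounds 1, 2 and 3 stay within the scatter of one another, while compound 4 alone stands apart as the weakest inhibitor of growth of the four, though each step to it is only modest. Nothing available here accounts for this gap.

The compounds shown leave open whether the step comes from the methoxy group itself or from the other differences between 3-methoxyphenyl and the three earlier groups. A plain phenyl group, or a hydroxyl group in place of the methoxy group, would help separate these possibilities.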